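Diamino core series: chain-linked aryl swap from compound 1 to compound 3

The compounds below may be only part of what the source reports. "The series", "measured", "known", "first", "only" and "open" are said of these compounds alone.

Compound 1 `Nc1cc(N)c2nc(-c3ccccc3)c(NCc3ccc(Cl)c(Cl)c3)nc2c1` carries a benzyl-type amine on the shared core. In a functional assay on KM12 cells (Homo sapiens) for inhibition, read by sulforhodamine B assay, with a stated time of 48 h (on this read-out higher numbers stand for lower toxicity in this test and lower numbers for higher toxicity in this test), compound 1 gives < 100000 nM, which is a limit of the assay and not a number. Compound 2 `Nc1cc(N)c2nc(-c3ccccc3)c(Sc3ccc(F)cc3)nc2c1` is the other measured member of the series. In this assay compound 2 also returns < 100000 nM, again a limit rather than a number. Within the data shown here, both recorded values therefore sit at the limit of < 100000 nM in this assay, at which 2 of the 2 values shown sit, so no measured step between compounds is available and compound 1 cannot be placed relative to anything on a numerical scale.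

Compound 3 `COc1ccc(CNc2nc3cc(N)cc(N)c3nc2-c2ccccc2)cc1OC` is not yet measured. It differs from compound 1 by 3,4-dimethoxyphenyl in place of 3,4-dichlorophenyl on a saturated chain carbon bound to a nitrogen on an aromatic ring. With only limits in hand, the step is expected to be small or absent beyond the scatter, and a step that the limit leaves unreadable from compound 1 to compound 3 is the estimate for it. For compound 3 the expected value in this assay is 30000 nM, with a range from 3000 nM to 100000 nM, and most likely another limit.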

Compound 3, concentration lethal to 50% of the cells: 72400 nM
Compound 3: the middle estimate sits 2.4-fold (0.38 log units) below what was measured, and the stated range covers the measured number.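

No step can be read from compound 1 to compound 3 in this assay. Compound 1 stands there only as a limit of the assay, not a number. The compounds shown leave open whether 3,4-dimethoxyphenyl in place of 3,4-dichlorophenyl changes the read-out at all.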